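The source may hold more compounds than are shown below. What is called first, only, known or untested is meant among the compounds shown, and "the series" means these compounds.

Measured in a functional assay on 143B cells (Homo sapiens) for inhibition, read by MTT assay, with a stated time of 72 h; on this read-out higher numbers stand for weaker inhibition and lower numbers for stronger inhibition:
- compound 1 `O=C(CCC(=O)OCCCCCCSc1ccc([N+](=O)[O-])c2nonc12)Nc1cccc(Cl)c1`: 2890 nM
- compound 2 `O=C(CCC(=O)OCCCCCCSc1ccc([N+](=O)[O-])c2nonc12)Nc1ccc(F)cc1`: 2500 nM
- compound 3 `COc1ccc(NC(=O)CCC(=O)OCCCCCCSc2ccc([N+](=O)[O-])c3nonc23)cc1`: 3060 nM

Compound 3, at 3060 nM, lies within the scatter of both other compounds, so the series shows no separation so far. Compound 4 `CN(C)CCNC(=O)CCC(=O)OCCCCCCSc1ccc([N+](=O)[O-])c2nonc12` has 2-(dimethylamino)ethyl in place of 4-methoxyphenyl on an amide-type nitrogen.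

Among the compounds with values here, three measured steps bear on this change: a 1.2-fold lower number from compound 1 to compound 2 (0.06 log units; within the scatter), a 1.1-fold higher number from compound 1 to compound 3 (0.02 log units; within the scatter) and a 1.2-fold higher number from compound 2 to compound 3 (0.09 log units; within the scatter). All three are small, but each only exchanges one substituted phenyl for another. Within the data shown here, no measured step removes the aromatic ring from this nitrogen, so they guide this change only loosely, and the range must stay wide.

In this assay, going by these compounds, no clear step beyond the scatter is expected, and the direction remains open. The expected step is a 1.2-fold lower number from compound 3 to compound 4 (0.09 log units; within the scatter). For compound 4 the estimated value is 2500 nM, with an expected range from 800 nM to 7000 nM.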

Compound 4, half-maximal inhibitory concentration: 2190 nM
Compound 4: middle estimate off by 1.1-fold (0.06 log units), on the high side; the range from low to high includes it.
By their numbers in this assay, from the lowest: compounds 4, 2, 1 and 3 (each within the scatter of the next).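

In this assay the aromatic ring on the amide-type nitrogen proves dispensable: 2-(dimethylamino)ethyl, which has no ring, gives a 1.4-fold lower number from compound 3 to compound 4 (0.15 log units; within the scatter), a 1.1-fold lower number from compound 2 to compound 4 (0.06 log units; within the scatter) and a 1.3-fold lower number from compound 1 to compound 4 (0.12 log units; within the scatter), all within the scatter. The position therefore accepts an open chain as well as the three substituted phenyl groups, and the four compounds still show no separation. Nothing available on these compounds accounts for this flat result.

Going by these compounds, it remains open whether a carboxylic acid, a primary amine or a longer chain on this nitrogen would move the number beyond the scatter. On these data alone, it is also open whether a change to the shared core would move it further than any exchange on this nitrogen has so far.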